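A few compounds are considered here, and "the series" means these few. Any claim that something is new, unique, unknown or untested is made for them only; others in the source may bear on it.

Measured in a functional assay on NCI/ADR-RES cells (Homo sapiens) for inhibition; a lower number here means a stronger inhibitor of growth, a higher number a weaker inhibitor of growth:
- compound 1 (`O=C(/C=C/c1cccc(O)c1)c1cccc(-n2cc(-c3ccccc3)[nH]c2=O)c1`): 3730 nM
- compound 2 (`O=C(/C=C/c1cccc(O)c1)c1cccc(-n2cc(-c3ccc(Cl)cc3)[nH]c2=O)c1`): 2200 nM

Going by the values given here, only these two compounds have numbers so far. Compound 2 lies within the usual scatter of compound 1, so the two cannot be ranked. Among the compounds with values here, the one measured step is a 1.7-fold lower number from compound 1 to compound 2 (0.23 log units; within the scatter), and it comes from chloro in place of hydrogen on an aromatic carbon.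

The next compound is compound 3 (`COc1cc(/C=C/C(=O)c2cccc(-n3cc(-c4ccc(Cl)cc4)[nH]c3=O)c2)ccc1O`), which carries 4-hydroxy-3-methoxyphenyl in place of 3-hydroxyphenyl on a double-bonded chain carbon bound to a double-bonded chain carbon. Within the data shown here, no measured step involves this change, so the data give it no size of its own. The chloro step does not bear on it directly, and it offers only a modest reference, at a 1.7-fold lower number from compound 1 to compound 2 (0.23 log units; within the scatter). In this assay, no step beyond the scatter is therefore expected, in either direction, and compound 2 at 2200 nM remains the anchor. The step expected is a 1.1-fold lower number from compound 2 to compound 3 (0.04 log units; within the scatter). For compound 3 the estimated value is 2000 nM, with an expected range from 700 nM to 6000 nM.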

Compound 3, concentration for 50% growth inhibition: 2280 nM
The estimate for compound 3 lay 1.1-fold (0.06 log units) below the measured number, within the range that was stated.
By their numbers in this assay, from the lowest: compounds 2, 3 and 1 (each within the scatter of the next).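

In this assay, going by these compounds alone, the first change at this place, on a double-bonded chain carbon bound to a double-bonded chain carbon, comes to a 1.0-fold higher number from compound 2 to compound 3 (0.02 log units; within the scatter). In this one pair, 4-hydroxy-3-methoxyphenyl, with 9 heavy atoms and 2 hydrogen-bond acceptors, thus stands in for 3-hydroxyphenyl, with 7 heavy atoms and 1 hydrogen-bond acceptor, without a step beyond the scatter, so the group at this place can be exchanged for a larger one while the number stays within the scatter. No measured evidence is available that would account for this result.

The compounds shown leave open whether the same exchange would read alike on compound 1, which carries hydrogen where compound 2 and compound 3 carry chloro. They also leave open whether any group at this place moves the number beyond the scatter, for instance a phenyl ring bearing an amine or a carboxylic acid, or a longer chain in place of the aromatic ring.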